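A few compounds are considered here, and "the series" means these few. Any claim that something is new, unique, unknown or untested is made for them only; others in the source may bear on it.

The three measured compounds and their results:

compound 1 `O=C(Nc1cccc(-n2cc(-c3ccncc3)c(-c3ccc(Cl)c(O)c3)n2)c1)Nc1ccc(Cl)c(Cl)c1` — 5210 nM
compound 2 `COc1cc(-c2nn(-c3cccc(NC(=O)c4ccc(Cl)c(C(F)(F)F)c4)c3)cc2-c2ccncc2)ccc1Cl` — > 32500 nM
compound 3 `COc1cc(-c2nn(-c3cccc(NC(=O)c4ccccc4)c3)cc2-c2ccncc2)ccc1Cl` — > 100000 nM

Within the data shown here, in a functional assay on UACC-62 cells (Homo sapiens) for inhibition, read by sulforhodamine B assay, with a stated time of 48 h (on this read-out lower numbers stand for stronger inhibition of growth and higher numbers for weaker inhibition of growth), compound 1 gives 5210 nM, the only plain number among the three results. Compound 2 reaches only a limit of the assay. Compound 3 likewise reaches only a limit. Among the measured compounds shown here, the one single-point step, a step that the two limits leave unreadable from compound 2 to compound 3, therefore cannot be read. Compound 4 `O=C(Nc1cccc(-n2cc(-c3ccncc3)c(-c3ccc(Cl)c(O)c3)n2)c1)Nc1ccc(Cl)c(C(F)(F)F)c1` differs from compound 1 by trifluoromethyl in place of chloro on an aromatic carbon. For the measured compounds named here, no measured step covers this change, and compound 2, which also carries a 4-chloro-3-(trifluoromethyl)phenyl group, differs from compound 1 in several other places at once, so it says nothing about this step on its own. The expected step is a 1.2-fold lower number from compound 1 to compound 4 (0.06 log units; within the scatter), no larger than the usual scatter. Compound 4 is estimated at 4500 nM, between 1500 nM and 14000 nM.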

Compound 4, concentration for total growth inhibition: 1450 nM
The estimate for compound 4 lay 3.1-fold (0.49 log units) above the measured number, outside the stated range (below it).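

In this assay, trifluoromethyl in place of chloro, ortho to a chloro group, gives a 3.6-fold lower number from compound 1 to compound 4 (0.56 log units; beyond the scatter). Among these compounds, this is the first readable step, and it shows that this position responds to the change, modestly but beyond the scatter. Nothing measured here explains the step.

This single pair leaves open whether the same change would give a similar step on a different core. It also leaves open how a methyl, a nitrile or an amine at this position would compare with chloro and trifluoromethyl.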